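Swapping Chloro for Methoxy on Two Related Cores

The source may hold more compounds than are shown below. What is called first, only, known or untested is meant among the compounds shown, and "the series" means these compounds.

Compound 1 `Cc1cc(C)c2c(O)cc(-c3ccc(Cl)cc3)nc2n1` is tested in a functional assay on 786-0 cells (Homo sapiens) (a higher number here means a weaker inhibitor of growth, a lower number a stronger inhibitor of growth), and gives 21400 nM. Compound 2 `COc1ccc(-c2cc(O)c3c(C)cc(C)nc3n2)cc1` differs from it by methoxy in place of chloro on an aromatic carbon and in this assay compound 2 gives 58900 nM, so that a 2.8-fold higher number from compound 1 to compound 2 (0.44 log units; beyond the scatter). Compound 3 `Cc1cnc2nc(-c3ccc(Cl)cc3)cc(O)c2c1` carries the same chloro group on a different core; how the core of compound 3 differs from the core of compound 1 is not broken down here. In this assay compound 3 gives 6310 nM, the lowest number of the three measured compounds. Among the measured compounds shown here, compound 4 `COc1ccc(-c2cc(O)c3cc(C)cnc3n2)cc1` is not yet measured; it differs from compound 3 by methoxy in place of chloro on an aromatic carbon, the same change as the one from compound 1 to compound 2. Because a 2.8-fold higher number from compound 1 to compound 2 (0.44 log units; beyond the scatter) on the first core, a step of similar size is expected on the second core, and the expected step is a 2.8-fold higher number from compound 3 to compound 4 (0.44 log units; beyond the scatter). The expectation rests on a single earlier example, so the range is kept wide. Compound 4 is expected to give about 17500 nM in this assay, with a range from 8000 nM to 40000 nM.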

Compound 4, concentration for 50% growth inhibition: 5130 nM
Compound 4: middle estimate off by 3.4-fold (0.53 log units), on the high side, and the stated range ends above it.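

On the core of compound 3, methoxy in place of chloro on an aromatic carbon gives a 1.2-fold lower number from compound 3 to compound 4 (0.09 log units; within the scatter), so the two groups cannot be told apart on this core in this assay. The change therefore did not carry over from one core to the other with the same size in this series: the same change on two cores in this assay, a 2.8-fold higher number (0.44 log units; beyond the scatter) from compound 1 to compound 2 and a 1.2-fold lower number (0.09 log units; within the scatter) from compound 3 to compound 4, 3.4-fold (0.53 log units) apart, beyond the scatter of two such steps. Among the compounds shown here, this shows that a step measured on one core was a poor guide to the step on the other, but with only one pair on each core it does not show which feature of the cores lies behind the gap, nor does it give a rule for any further core.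

The compounds shown carry only chloro or methoxy at this place, so how an amine, a carboxylic acid or a longer chain such as ethoxy would behave on either core remains open. Also open, on these data alone, is whether the two cores would part in the same way for those groups, or whether the gap is particular to this one swap.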